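Swapping the aryl group on the sulfonyl sulfur

The source may report more compounds than this note shows. Statements on the series, on what has been measured and on what is new or still open speak of the compounds shown alone.

Three compounds sharing one core were measured in a physicochemical assay for permeability, using PAMPA, at pH 7.4 (on this read-out higher numbers stand for higher permeability and lower numbers for lower permeability), and a fourth awaits measurement:

Compound 1 `O=C(NS(=O)(=O)c1ccc(F)cc1)c1ccc(Nc2nc(NC3(c4ccc(Cl)cc4)CC3)nc(OCC(F)(F)F)n2)cc1` gave 193 nm/s.
Compound 2 `CNC(=O)NCCS(=O)(=O)NC(=O)c1ccc(Nc2nc(NC3(c4ccc(Cl)cc4)CC3)nc(OCC(F)(F)F)n2)cc1` gave 40 nm/s.
Compound 3 `NCCS(=O)(=O)NC(=O)c1ccc(Nc2nc(NC3(c4ccc(Cl)cc4)CC3)nc(OCC(F)(F)F)n2)cc1` gave 153 nm/s.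

Compound 1 stands highest of the three numbers in this assay. Its nearest neighbour is compound 3, and the step of a 1.3-fold lower number from compound 1 to compound 3 (0.10 log units; within the scatter) lies within the scatter, so the two cannot be ranked. The furthest is compound 2, with a 4.8-fold lower number from compound 1 to compound 2 (0.68 log units; beyond the scatter), and between the two chain variants the step of a 3.8-fold higher number from compound 2 to compound 3 (0.58 log units; beyond the scatter) is also beyond the scatter.

Compound 4 `Cc1ccccc1S(=O)(=O)NC(=O)c1ccc(Nc2nc(NC3(c4ccc(Cl)cc4)CC3)nc(OCC(F)(F)F)n2)cc1` differs from compound 1 in one place: 2-methylphenyl in place of 4-fluorophenyl on a sulfonyl sulfur. Both measured steps away from compound 1 replace the 4-fluorophenyl with an ethyl chain carrying donors and acceptors; the change to compound 4 instead keeps an aromatic ring of seven heavy atoms with no donors or acceptors and no charge. Among the compounds with values here, no measured step trades one such aryl for another, so the pair with compound 3, a 1.3-fold lower number from compound 1 to compound 3 (0.10 log units; within the scatter), is the closer guide: a change that leaves the donor and acceptor count untouched gave no step beyond the scatter. Compound 4 is therefore expected to sit near compound 1, with the step of a 1.0-fold higher number from compound 1 to compound 4 (0.02 log units; within the scatter) estimated to stay within the scatter. The estimate for compound 4 in this assay is 200 nm/s, expected between 100 nm/s and 400 nm/s.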

Compound 4, apparent permeability: 265 nm/s
Beside the measured number, compound 4's estimate is 1.3-fold (0.12 log units) below it; the range from low to high includes it.
By their numbers in this assay, from the lowest: compound 2; then compounds 3, 1 and 4 (each within the scatter of the next).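

Trading one aryl group for another on the sulfonyl sulfur, 2-methylphenyl in place of 4-fluorophenyl, gave a 1.4-fold higher number from compound 1 to compound 4 (0.14 log units; within the scatter) in this assay, so the two aromatic rings cannot be told apart on this read-out. The 2-aminoethyl chain cannot be told apart from the 2-methylphenyl group either, with a 1.7-fold higher number from compound 3 to compound 4 (0.24 log units; within the scatter), which places compounds 1, 3 and 4 within the scatter of one another. Only the 2-((methylcarbamoyl)amino)ethyl chain stands apart, now against a second aryl group as well, with a 6.6-fold higher number from compound 2 to compound 4 (0.82 log units; beyond the scatter), but nothing available here accounts for any of these numbers.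

The compounds shown leave open whether a plain methyl, a longer alkyl chain, or an aryl ring carrying a carboxylic acid or an amine on the sulfonyl sulfur would stay with compounds 1, 3 and 4. Also open, going by these compounds, is which part of the methylcarbamoyl group sets compound 2 apart, a question that an acetyl group on the same amine nitrogen, or a longer chain ending in the amine, could address.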